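The source may hold more compounds than are shown below. What is called first, only, known or untested is meant among the compounds shown, and "the series" means these compounds.

Working notes on the series.

Compound 1 `COc1cc(/C=C2\SC(=O)NC2=O)ccc1OCN1C(=O)c2ccccc2C1=O` is the reference point. In an assay on isolated protein for inhibition of Alpha glucosidase (Homo sapiens), read by spectrophotometry, with stated times of 15 min and 30 min (a lower number here means a stronger inhibitor, a higher number a weaker inhibitor), compound 1 gives 35100 nM. Compound 2 `COc1cc(/C=C2\SC(=O)NC2=O)cc(OC)c1OCN1C(=O)c2ccccc2C1=O` carries one further change, (methoxy in place of hydrogen on an aromatic carbon). In this assay compound 2 reaches only the limit of the assay, > 100000 nM. The step is therefore an at least 2.8-fold higher number from compound 1 to compound 2 (0.45 log units; beyond the scatter), a weakening that is beyond the usual scatter, though its full size is not known since the second value is a limit.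

Compound 3 `O=C1NC(=S)S/C1=C\c1ccccc1OCN1C(=O)c2ccccc2C1=O` has a different core; the difference between the two cores is not broken down here. In this assay compound 3 also sits at the limit of the assay, > 100000 nM.

Compound 4 `COc1cccc(/C=C2\SC(=S)NC2=O)c1OCN1C(=O)c2ccccc2C1=O` is not yet measured. It differs from compound 3 by methoxy in place of hydrogen on an aromatic carbon. This is the same kind of change as from compound 1 to compound 2, though not the same: in compound 1 the entering methoxy also stands meta to a methoxy group (2 heavy atoms), which compound 3 lacks.

The expected step is a step that the limit leaves unreadable from compound 3 to compound 4, and it rests on (the limit of > 100000 nM in this assay, at which 2 of the 3 values shown sit), since compound 3 already gives only a limit and the earlier step weakened compound 1 further. Compound 4 is thus estimated at 150000 nM, with a range from 60000 nM to 400000 nM, most likely again reported only as a limit.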

Compound 4, half-maximal inhibitory concentration: > 100000 nM
Compound 4 gave a limit, no number (the forecaster's own chance of this, stated with the estimate: 85%); the middle value lies beyond the limit too.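

Compound 3 and compound 4 both give only a limit, not a number, so no step can be read between them: the limit of > 100000 nM in this assay, at which 3 of the 4 values shown sit.

The compounds shown leave open what methoxy in place of hydrogen on an aromatic carbon does on the core of compound 3, and how compound 2, compound 3 and compound 4 rank against one another.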